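The source may report more compounds than this note shows. Statements on the series, on what has been measured and on what is new or still open speak of the compounds shown alone.

Compound 1 `COc1ccc(/C(=N/O)c2cccc3ccccc23)c(OC)c1OC` in a functional assay on THP-1 cells (Homo sapiens) for inhibition, read by sulforhodamine B assay, with a stated time of 48 h; a lower number here means a stronger inhibitor, a higher number a weaker inhibitor: > 20000 nM, a limit of the assay.
Compound 2 `COC(=O)c1ccc(COC(c2ccc(OC)c(OC)c2OC)c2cccc3ccccc23)cc1` in this assay: > 20000 nM, likewise a limit.

Compound 1 therefore stands at no measured number in this assay but only at a limit, and the whole picture so far is the limit of > 20000 nM in this assay, at which 2 of the 2 values shown sit. Compound 3 `COc1ccc(/C(=N/OCC(=O)O)c2cccc3ccccc23)c(OC)c1OC` differs from compound 1 by carboxymethyl in place of hydrogen on an oxygen. Among the compounds with values here, no measured pair here shows what such a change does. The expected step that the limit leaves unreadable from compound 1 to compound 3 is none beyond the scatter, resting on compound 1 at > 20000 nM. Compound 3 is estimated at 30000 nM, between 5000 nM and 150000 nM, most likely again only a limit.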

Compound 3, half-maximal inhibitory concentration: > 20000 nM
Compound 3 ended at the assay's limit; the forecaster's own chance of this, stated with the estimate: 80%; the middle value lies beyond the limit too.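

Compound 1 and compound 3 both end at a limit of the assay, so no step can be read between them: the limit of > 20000 nM in this assay, at which 3 of the 3 values shown sit.

The compounds shown leave open what carboxymethyl in place of hydrogen on that oxygen does to inhibition.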